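The source may hold more compounds than are shown below. What is called first, only, known or untested is meant among the compounds shown, and "the series" means these compounds.

In a functional assay on HeLa cells (Homo sapiens) for antiproliferative activity, read by MTT assay, with a stated time of 48 h (on this read-out lower numbers stand for stronger inhibition and higher numbers for weaker inhibition), compound 1 `CN(C)CCn1c(N)c(-c2nc3ccccc3[nH]2)c2nc(C#N)c(C#N)nc21` gives 8880 nM. Compound 2 `N#Cc1nc2c(-c3nc4ccccc4[nH]3)c(N)n(CCN3CCCC3)c2nc1C#N` reaches only the limit of this assay, > 50000 nM. Compound 3 `N#Cc1nc2c(-c3nc4ccccc4[nH]3)c(N)n(CCO)c2nc1C#N` likewise reaches only the limit of this assay, > 50000 nM. Compound 3 therefore stands at the weak end of the three, with a limit rather than a number of its own. Two steps lead away from compound 1 at the same place on the chain: an at least 5.6-fold higher number from compound 1 to compound 2 (0.75 log units; beyond the scatter), and an at least 5.6-fold higher number from compound 1 to compound 3 (0.75 log units; beyond the scatter). Between the two limit compounds, a step that the two limits leave unreadable from compound 2 to compound 3, which stays unreadable due to the limit of > 50000 nM in this assay, at which 2 of the 3 values shown sit. Compound 4 `N#Cc1nc2c(-c3nc4ccccc4[nH]3)c(N)n(CCCNc3ccccc3)c2nc1C#N` differs from compound 3 by anilinomethyl in place of hydroxy on a saturated chain carbon, two bonds along the chain from an aromatic nitrogen. For the measured compounds named here, no measured step puts an anilinomethyl group at this place, so the steps from compound 1 show only that two replacements of the dimethylamino group both made the number rise, and they give no direction for a third. The expected step is an at least 1.6-fold lower number from compound 3 to compound 4 (0.22 log units; that floor lies within the scatter), set close to the limit and with wide bounds. Compound 4 is therefore estimated at 30000 nM in this assay, with a range from 5000 nM to 100000 nM, and a real chance that only a limit is again reported.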

Compound 4, half-maximal inhibitory concentration: 26300 nM
Estimate against measurement, compound 4: 1.1-fold (0.06 log units) above; the range from low to high includes it.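

In this assay compound 4, which carries 3-anilinopropyl at this place, gives 26300 nM, so a chain ending in an aromatic ring of carbon still yields a number of its own on this read-out. Set against the two compounds that reach only a limit, the change reads as an at least 1.9-fold lower number from compound 3 to compound 4 (0.27 log units; that floor lies within the scatter) and as an at least 1.9-fold lower number from compound 2 to compound 4 (0.27 log units; that floor lies within the scatter); both floors lie within the scatter, so neither establishes a real gain. For the compounds shown here, the one new step with a measured value at both ends is a 3.0-fold higher number from compound 1 to compound 4 (0.47 log units; beyond the scatter), which means that anilinomethyl joins pyrrolidin-1-yl and hydroxy as a replacement for dimethylamino that raises the number, and compound 1 keeps the lowest value of the four.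

On these data alone, it remains open whether another small open-chain amine on the same chain, such as diethylamino or methylamino, would match or improve on dimethylamino, and whether a phenyl ring without the anilino nitrogen would behave as anilinomethyl does. The step from compound 2 to compound 3 still cannot be read: the limit of > 50000 nM in this assay, at which 2 of the 4 values shown sit.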